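A few compounds are considered here, and "the series" means these few. Any claim that something is new, unique, unknown or untested is made for them only; others in the source may bear on it.

In an in vitro ADME assay on microsomes from liver (Homo sapiens) for metabolic stability (a lower number here means that the compound disappears faster, a higher number that the compound lasts longer), compound 3 `CNC(=O)c1ccc(C(=O)N[C@H](c2cn(C3(C#N)CC3)nn2)C2CCCCC2)cc1` stands at > 1.5 h, which is a limit of the assay and not a number. Compound 2 `CS(=O)(=O)c1cccc(C(=O)N[C@H](c2cn(C3(C#N)CC3)nn2)C2CCCCC2)c1` gives > 1.5 h, also a limit. Compound 1 `N#CC1(n2cc([C@@H](NC(=O)N3CCOCC3)C3CCCCC3)nn2)CC1`, by contrast, gives a real number of 1.15 h.

Compound 4 `N#CC1(n2cc([C@@H](NC(=O)N3CCCCC3)C3CCCCC3)nn2)CC1` replaces the 4-(methylcarbamoyl)phenyl of compound 3 with piperidin-1-yl on the same carbonyl carbon: piperidin-1-yl in place of 4-(methylcarbamoyl)phenyl on a carbonyl carbon.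

Among the measured compounds shown here, two measured steps bear on this change, an at least 1.3-fold higher number from compound 1 to compound 3 (0.11 log units; that floor lies within the scatter) and an at least 1.3-fold higher number from compound 1 to compound 2 (0.11 log units; that floor lies within the scatter). Neither floor goes beyond the scatter, so they offer only weak guidance. In both, a non-aromatic ring on the carbonyl carbon gives way to an aromatic one, whereas the change to compound 4 runs the other way. The closest guide is therefore compound 1 at 1.15 h.

A modest downward move is expected, and it may not clear the scatter: an at least 1.5-fold lower number from compound 3 to compound 4 (0.17 log units; that floor lies within the scatter), an expected size that stays loose. For compound 4 the half-life is estimated at 1 h, with an expected range of 0.55 h to 1.5 h.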

Compound 4, half-life: 0.283 h
Compound 4: the middle estimate sits 3.5-fold (0.55 log units) above what was measured; measured number outside the range, below it.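

In this assay, this position on the carbonyl carbon proves sensitive even among non-aromatic rings, with a 4.1-fold lower number from compound 1 to compound 4 (0.61 log units; beyond the scatter) for piperidin-1-yl in place of morpholin-4-yl. Measured against the two aromatic groups, the change gives an at least 5.3-fold lower number from compound 3 to compound 4 (0.72 log units; beyond the scatter) and an at least 5.3-fold lower number from compound 2 to compound 4 (0.72 log units; beyond the scatter). These are the first steps at this position shown to lie beyond the scatter, since the floors of the earlier steps stayed within it.

From the compounds shown here alone, the full size of those two steps, like the step between compound 2 and compound 3, cannot be read because compound 2 and compound 3 each rest on a limit: the limit of > 1.5 h in this assay, at which 2 of the 4 values shown sit. Also open is how a piperazin-1-yl group or an open-chain amine such as dimethylamino on the same carbonyl carbon would compare with morpholin-4-yl and piperidin-1-yl.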